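The source may hold more compounds than are shown below. What is called first, only, known or untested is meant among the compounds shown, and "the series" means these compounds.

Measured in an assay on HEK293 cells for positive allosteric modulation of metabotropic glutamate receptor 2 (Rattus norvegicus), read by thallium flux, with a stated time of 2.5 min; on this read-out higher numbers stand for an effect only at larger amounts of compound and lower numbers for an effect already at smaller amounts:
compound 1 `Cc1c(OCCCCOc2ccccc2C(=O)O)ccc(C(=O)CC2CCCC2)c1C` gives 2580 nM
compound 2 `Cc1c(OCCCCOc2ccccc2C(=O)O)ccc(C(=O)CC(C)C)c1O` gives 415 nM
compound 3 `Cc1c(OCCCCOc2ccccc2C(=O)O)ccc(C(=O)CC2CCCC2)c1O` gives 335 nM

Compound 3 has the lowest number of the three. Compound 2 stands within the scatter of it, as the step of a 1.2-fold lower number from compound 2 to compound 3 (0.09 log units; within the scatter) shows, while compound 1 sits well apart: a 7.7-fold lower number from compound 1 to compound 3 (0.89 log units; beyond the scatter). Compound 4 `Cc1c(OCCCCOc2ccc(C(=O)O)cc2F)ccc(C(=O)CC2CCCC2)c1O` differs from compound 3 in one place: 4-carboxy-2-fluorophenyl in place of 2-carboxyphenyl on an oxygen on a saturated carbon. Neither measured step touches this part of the molecule; one concerns hydroxy in place of methyl on an aromatic carbon, the other cyclopentyl in place of isopropyl on a saturated chain carbon bound to a carbonyl carbon. Within the data shown here, no measured step bears on the change, and the series gives no direction for this assay. The expected step of a 1.3-fold higher number from compound 3 to compound 4 (0.13 log units; within the scatter) is estimated to remain within the scatter, with wide uncertainty. Compound 4 is estimated at 450 nM, range 150 nM to 1500 nM.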

Compound 4, half-maximal effective concentration: 639 nM
Compound 4: the middle estimate sits 1.4-fold (0.15 log units) below what was measured, and the stated range covers the measured number.
By their numbers in this assay, from the lowest: compounds 3, 2 and 4 (each within the scatter of the next); then compound 1.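

In this assay the replacement of 2-carboxyphenyl by 4-carboxy-2-fluorophenyl gives a 1.9-fold higher number from compound 3 to compound 4 (0.28 log units; within the scatter) and so does not move the number beyond the scatter. Among these compounds, this is the only reading at this place, on an oxygen on a saturated carbon, since the earlier steps concerned other parts of the molecule. Nothing shown accounts for this result.

Going by these compounds, the fluorine and the shifted carboxy group enter together, so their separate contributions remain open. Also open, on these data alone, is how an amide or a tetrazole in place of the carboxylic acid would read at this place.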